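This account rests on a few compounds, and the source may have more. Where it says the series, first, only, none or still open, it means among the compounds named here.

Compound 1 `O=C(O)c1cc(-c2c[nH]cn2)ccc1O`: 100 mg/kg in a functional assay on the whole organism for inhibition, with Rattus norvegicus as the target, read by paw edema; a lower number here means that less compound is needed, a higher number that more compound is needed for the effect.
Compound 2 `CC(=O)Oc1ccc(-n2cccc2)cc1C(=O)O`: 42 mg/kg in this assay.

Compound 1 carries the highest of the two numbers; the gap to compound 2 lies beyond the scatter, but the two compounds differ in more than one place, so no single step can be read from them. Compound 3 `O=C(O)c1cc(-c2ccns2)ccc1O` differs from compound 1 by 1,2-thiazol-5-yl in place of 1H-imidazol-4-yl on an aromatic carbon. With no comparable change measured in this assay, no step beyond the scatter is expected in either direction. The estimate for compound 3 in this assay is 90 mg/kg, range 40 mg/kg to 200 mg/kg. This corresponds to an expected step of a 1.1-fold lower number from compound 1 to compound 3 (0.05 log units; within the scatter).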

Compound 3, dose for half-maximal effect: 80 mg/kg
Beside the measured number, compound 3's estimate is 1.1-fold (0.05 log units) above it; measured number inside the range.
By their numbers in this assay, from the lowest: compounds 2, 3 and 1 (each within the scatter of the next, the first and the last beyond it).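

At the aromatic carbon para to the hydroxy group, 1,2-thiazol-5-yl in place of 1H-imidazol-4-yl gives a 1.3-fold lower number from compound 1 to compound 3 (0.10 log units; within the scatter) in this assay. This position therefore accepts one five-membered aromatic ring with 2 hetero atoms in place of another, even as the group goes from 1 hydrogen-bond donor to 0 and gains a sulfur, with no step beyond the scatter. Nothing available explains this result.

Still open, as far as these compounds go, is whether a six-membered ring such as phenyl would be accepted here. From the compounds shown here alone, an amine or a longer alkyl chain at this carbon is equally open.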